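Chain Lengthening on Two Related Cores

This account rests on a few compounds, and the source may have more. Where it says the series, first, only, none or still open, it means among the compounds named here.

Compound 1 `COc1ccc2cc(CO)oc(=O)c2c1` and compound 2 `COc1ccc2cc(CCCO)oc(=O)c2c1` share one core, while compound 3 `COc1ccc2c(c1)C(=O)OC(CO)C2` and compound 4 `COc1ccc2c(c1)C(=O)OC(CCCO)C2` share another; the difference between the two cores is not broken down here. In a functional assay on MCF7 cells (Homo sapiens) for antiproliferative activity, read by sulforhodamine B assay, with a stated time of 48 h (a higher number here means a weaker inhibitor of growth, a lower number a stronger inhibitor of growth), compound 1 gives 32.6 ug/mL, and compound 2 gives 25.8 ug/mL. The change between them, (2-hydroxyethyl in place of hydroxy on a saturated chain carbon bound to an aromatic carbon), made a step of a 1.3-fold lower number from compound 1 to compound 2 (0.10 log units; within the scatter). Compound 3 gives 250 ug/mL in this assay, the highest of the three numbers, and its gaps to compound 1 and to compound 2 both lie beyond the scatter. Compound 4 carries the same kind of change relative to compound 3, (2-hydroxyethyl in place of hydroxy on a saturated chain carbon bound to a saturated ring carbon); the surroundings differ, the saturated chain carbon being bound to a saturated ring carbon rather than to an aromatic carbon. Since the same change on the first core stayed within the scatter, the expected step from compound 3 to compound 4 is a 1.3-fold lower number from compound 3 to compound 4 (0.10 log units; within the scatter), resting on a 1.3-fold lower number from compound 1 to compound 2 (0.10 log units; within the scatter). Compound 4 is therefore estimated at 200 ug/mL, with a range from 100 ug/mL to 400 ug/mL.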

Compound 4, concentration for 50% growth inhibition: 80.8 ug/mL
Compound 4: the middle estimate sits 2.5-fold (0.39 log units) above what was measured; measured number outside the range, below it.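

The change from hydroxymethyl to 3-hydroxypropyl gave a 3.1-fold lower number from compound 3 to compound 4 (0.49 log units; beyond the scatter) in this assay, against a 1.3-fold lower number from compound 1 to compound 2 (0.10 log units; within the scatter) on the other core. Only the new step lies beyond the scatter, yet the two steps cannot be told apart: the same change on two cores in this assay, a 1.3-fold lower number (0.10 log units; within the scatter) from compound 1 to compound 2 and a 3.1-fold lower number (0.49 log units; beyond the scatter) from compound 3 to compound 4, 2.4-fold (0.39 log units) apart, within the scatter of two such steps This shows that the change carried from one core to the other without a demonstrable difference in its effect, but with a single pair on each core it does not show that the two steps are equal, nor that the saturated ring carbon in the new surroundings leaves the step unaltered, nor that lengthening the chain lowers the number in general.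

The compounds shown leave open whether a longer chain than 3-hydroxypropyl, or an amine or a carboxylic acid in place of the hydroxy, would move the number on either core. They also leave open whether the two steps would stay this close with any other chain length.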